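This account rests on a few compounds, and the source may have more. Where it says the series, first, only, none or still open, it means among the compounds named here.

Of the compounds shown here, two have numbers so far in a functional assay on HCT-116 cells (Homo sapiens) for antiproliferative activity, read by MTT assay, with a stated time of 48 h; a lower number here means a stronger inhibitor, a higher number a weaker inhibitor. Compound 1 (`COc1ccc(-c2cc3c(cn2)[nH]c(=O)n3-c2cc(OC)c(OC)c(OC)c2)cc1`) gives 840 nM. Compound 2 (`COc1ccc(-c2cc3c(cn2)n(C)c(=O)n3-c2cc(OC)c(OC)c(OC)c2)cc1O`) gives 1060 nM, which lies within the scatter of compound 1, so the two cannot be separated on the numbers shown. The next compound to be read is compound 3 (`COc1ccc(-c2cc3c(cn2)n(C(C)C)c(=O)n3-c2cc(OC)c(OC)c(OC)c2)cc1O`). It departs from compound 2 by a single change, isopropyl in place of methyl on an aromatic nitrogen of the five-membered ring of the shared core: isopropyl in place of methyl on an aromatic nitrogen. For the measured compounds named here, no two measured compounds differ in one place only, so the series gives no direct guide to the size of this step. Going by the values given here, the only anchor is compound 2 at 1060 nM. In this assay a modest move towards weaker inhibition is expected, and a result within the scatter would be no surprise. The expected change is a 1.3-fold higher number from compound 2 to compound 3 (0.12 log units; within the scatter), and it is held loosely. For compound 3 the estimated value is 1400 nM, with an expected range from 450 nM to 4500 nM.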

Compound 3, half-maximal inhibitory concentration: 6660 nM
Estimate against measurement, compound 3: 4.8-fold (0.68 log units) below; the measured number lies above the stated range.
By their numbers in this assay, from the lowest: compounds 1 and 2 (each within the scatter of the next); then compound 3.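

In this assay the aromatic nitrogen of the five-membered ring proves sensitive to the group it carries: isopropyl in place of methyl gives a 6.3-fold higher number from compound 2 to compound 3 (0.80 log units; beyond the scatter), the first single-place step the series offers. The step is confined to an all-carbon group, with no ring, hydrogen-bond donor, hydrogen-bond acceptor or net charge entering or leaving, so a change of this kind at this position is enough to carry the number beyond the scatter towards weaker inhibition. Nothing at hand accounts for the size of this step.

The compounds shown leave open whether ethyl on this nitrogen would stand nearer to methyl or to isopropyl, and how a longer chain ending in an amine or a carboxylic acid would read here. Compound 1, with hydrogen on this nitrogen, also differs from compound 2 in a second place, so what methyl itself contributes at this position remains unresolved.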